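The compounds below may be only part of what the source reports. "The series", "measured", "known", "first", "only" and "open" are said of these compounds alone.

Measured so far in a functional assay for inhibition; a higher number here means a weaker inhibitor, a lower number a stronger inhibitor:
compound 1 `CC(C)(C)c1cc(-c2cc(=O)c3ccc(OCCO)cc3o2)cc(C(C)(C)C)c1O`, 3000 nM
compound 2 `CCOC(=O)COc1ccc2c(=O)cc(-c3cc(C(C)(C)C)c(O)c(C(C)(C)C)c3)oc2c1`, 3000 nM

Going by the values given here, compound 2 stands level with compound 1 in this assay; the single recorded step, no change at the digits printed from compound 1 to compound 2 (within the scatter), exchanged a group on the saturated chain carbon bound to an oxygen on an aromatic ring without moving the read-out. Compound 3 `CC(C)(C)c1cc(-c2cc(=O)c3ccc(OCC(=O)N4CCCCC4)cc3o2)cc(C(C)(C)C)c1O` alters the same chain further: piperidin-1-yl in place of ethoxy on a carbonyl carbon. Among the compounds with values here, no measured step covers this exact change; the one related step showed no effect. The expected step is therefore no change at the digits printed from compound 2 to compound 3 (within the scatter), none beyond the scatter. Compound 3 is estimated at 3000 nM, range 1000 nM to 9000 nM.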

Compound 3, half-maximal inhibitory concentration: 3000 nM
Estimate against measurement, compound 3: no gap at the digits printed; low and high end bracket the measured number.
By their numbers in this assay, from the lowest: compounds 1, 2 and 3 (each within the scatter of the next).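

In this assay, piperidin-1-yl in place of ethoxy on a carbonyl carbon gives no change at the digits printed from compound 2 to compound 3 (within the scatter), so a six-membered non-aromatic ring can stand on this carbonyl carbon without moving the read-out. (Piperidin-1-yl)carbonyl in place of hydroxymethyl gives no change at the digits printed from compound 1 to compound 3 (within the scatter), so all three chain ends shown read alike. No supporting data bear on this flat result.

Going by these compounds, whether a carboxylic acid, a free amine or a longer chain here would leave this level remains open. Also open, on these data alone, is whether changes to the shared core would move the read-out.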